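Amino in Place of Chloro on Two Related Compounds

This account rests on a few compounds, and the source may have more. Where it says the series, first, only, none or still open, it means among the compounds named here.

Compounds 1, 2 and 3 have been tested in a functional assay on SW-620 cells (Homo sapiens) for cytotoxicity, read by sulforhodamine B assay, with a stated time of 48 h; on this read-out lower numbers stand for higher toxicity in this test and higher numbers for lower toxicity in this test. Compound 1, `ClCc1ccccc1Cn1cnc2c(Cl)nc(Cl)nc21`, gives 810 nM in this assay. Compound 2, `ClCc1cccc(Cn2cnc3c(Cl)nc(Cl)nc32)c1`, is built from the same atoms joined differently; the difference between the two cores is not broken down here. In this assay compound 2 gives 7760 nM, the highest of the two numbers measured, with compound 1 the nearer one.

Compound 3, `Nc1nc(Cl)c2ncn(Cc3ccccc3CCl)c2n1`, differs from compound 1 by a single change: amino in place of chloro on an aromatic carbon. In this assay compound 3 reaches only > 100000 nM, which is a limit of the assay and not a number. The step of an at least 120-fold higher number from compound 1 to compound 3 (2.09 log units; beyond the scatter) is therefore a large one, and it rests on (the limit of > 100000 nM in this assay, at which 1 of the 3 values shown sits).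

Compound 4, `Nc1nc(Cl)c2ncn(Cc3cccc(CCl)c3)c2n1`, has not been measured yet. It relates to compound 2 exactly as compound 3 relates to compound 1: amino in place of chloro on an aromatic carbon. The place description is identical word for word, so this is the same change. Because the step of an at least 120-fold higher number from compound 1 to compound 3 (2.09 log units; beyond the scatter) was large, a comparable step is expected here, a 39-fold higher number from compound 2 to compound 4 (1.59 log units; beyond the scatter), which is an estimate and not a measurement. Since compound 2 already starts from a higher number than compound 1, compound 4 is expected to give about 300000 nM in this assay, quite possibly only a limit, with a plausible range from 60000 nM to 1500000 nM.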

Compound 4, concentration lethal to 50% of the cells: 57500 nM
The estimate for compound 4 lay 5.2-fold (0.72 log units) above the measured number, outside the stated range (below it).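

Amino in place of chloro gives a higher number on both cores, which here means lower toxicity in this test, and on the second core this assay shows a 7.4-fold higher number from compound 2 to compound 4 (0.87 log units; beyond the scatter). The direction of the change therefore carries over from one core to the other, but its size does not, and the two steps differ by more than repeated measurements would be expected to explain: the same change on two cores in this assay, an at least 120-fold higher number (2.09 log units; beyond the scatter) from compound 1 to compound 3 and a 7.4-fold higher number (0.87 log units; beyond the scatter) from compound 2 to compound 4, at least 16-fold (1.22 log units) apart, beyond the scatter of two such steps. Within the data shown here, the true size of the earlier step remains unknown, so the result shows only that the later step is the smaller of the two and not by exactly how much, and two pairs of compounds cannot show how the change would behave on any further core: the limit of > 100000 nM in this assay, at which 1 of the 4 values shown sits.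

As far as these compounds go, the four compounds carry only chloro or amino at this place, so it remains open how a methoxy group or a dimethylamino group there would read in this assay. Also open, from the compounds shown here alone, is what a methyl group or a hydroxymethyl group would do in place of the chloromethyl group that all four compounds share, and whether the difference between the two cores would persist with such a replacement.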